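The source may report more compounds than this note shows. Statements on the series, on what has been measured and on what is new or still open speak of the compounds shown alone.

Measured in an ADME assay on L1210/0 cells (Mus musculus) for cytotoxicity, with a stated time of 48 h; a higher number here means a weaker inhibitor, a lower number a stronger inhibitor:

- Compound 1 `Nc1ncnc2c1nnn2C1C[C@H](CO)[C@@H](CO)[C@@H]1CO`: > 200000 nM, a limit of the assay
- Compound 2 `COC1=C(OC)/C(=C/Cn2cnc3c(Cl)ncnc32)OC1=O`: 14000 nM
- Compound 3 `O=c1[nH]c(=O)n([C@H]2C[C@H](O)[C@@H](CO)O2)cc1CO`: 9180 nM

In this assay, compound 3 gives 9180 nM and compound 2 gives 14000 nM, so these two numbers lie within the usual scatter of each other. Going by the values given here, they are the only exact numbers in this small set. Compound 1 is reported only as a limit, > 200000 nM.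

The next compound, compound 4 `O=C(CI)NCc1cn([C@H]2C[C@H](O)[C@@H](CO)O2)c(=O)[nH]c1=O`, departs from compound 3 in one place. It has ((iodomethyl)carbonyl)amino in place of hydroxy on a saturated chain carbon bound to an aromatic carbon. Put another way, hydroxymethyl becomes (((iodomethyl)carbonyl)amino)methyl, while the rest of the structure stays the same.

Among the compounds with values here, no pair of measured compounds shows what a change of this kind does in this assay, so any forecast is loose. It can only start from compound 3 at 9180 nM, the closest measured structure. A moderate move towards a lower number, meaning a stronger inhibitor, is expected, though a result within the scatter of compound 3 would not be surprising. The estimated change is a 3.1-fold lower number from compound 3 to compound 4 (0.49 log units; beyond the scatter). For compound 4 the expected value is 3000 nM, with an estimated range of 300 nM to 30000 nM.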

Compound 4, half-maximal inhibitory concentration: 107000 nM
For compound 4 the middle estimate is 36-fold (1.55 log units) below the measured one; measured number above the stated range.
By their numbers in this assay, from the lowest: compounds 3 and 2 (each within the scatter of the next); then compound 4. At a limit, above all of these: compound 1.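

Replacing hydroxy on a saturated chain carbon bound to an aromatic carbon with ((iodomethyl)carbonyl)amino gives a 12-fold higher number from compound 3 to compound 4 (1.07 log units; beyond the scatter) in this assay. Going by these compounds alone, this is the first reading of any change at this place, and it shows that the place is not indifferent to what it carries: the swap of 1 heavy atom for 5 heavy atoms, iodine among them, moves the compound towards a weaker inhibitor and not towards a stronger one. Compound 4 nevertheless still reads as an exact number and not as a limit of the assay: the limit of > 200000 nM in this assay, at which 1 of the 4 values shown sits.

The compounds shown leave open which part of the entering group accounts for the step, since the amide link, the iodine and the added atoms all arrive together in this single change. A plain amine on the same chain carbon, or an acetylamino group, which keeps the carbonyl and drops the iodine, would help to separate these parts, and a chloroacetyl amide would show whether the identity of the halogen matters at all.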